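Compound 3 to compound 4: amino for hydroxy on the aryl

A few compounds are considered here, and "the series" means these few. Any claim that something is new, unique, unknown or untested is made for them only; others in the source may bear on it.

In a functional assay on MDA-MB-231 cells (Homo sapiens) for cytotoxicity, read by MTT assay, with a stated time of 48 h (on this read-out lower numbers stand for stronger inhibition and higher numbers for weaker inhibition), compound 3 `Oc1ccc(Nc2nc(-c3cccc(F)c3)nc3ccc(F)cc23)cc1` sits only at the limit > 50000 nM, which is a limit of the assay and not a number. Compound 1 `Fc1cccc(-c2nc(Nc3ccccc3F)c3cc(F)ccc3n2)c1` likewise gives only the limit > 50000 nM in this assay. Compound 2 `Fc1cccc(-c2nc(Nc3ccccc3Br)c3cc(F)ccc3n2)c1` also returns only the limit > 50000 nM. The steps a step that the two limits leave unreadable from compound 1 to compound 2, a step that the two limits leave unreadable from compound 1 to compound 3 and a step that the two limits leave unreadable from compound 2 to compound 3 are all unreadable in size, given (the limit of > 50000 nM in this assay, at which 3 of the 3 values shown sit). Compound 4 `Nc1ccccc1Nc1nc(-c2cccc(F)c2)nc2ccc(F)cc12` differs from compound 3 by 2-aminophenyl in place of 4-hydroxyphenyl on a nitrogen on an aromatic ring. Among the measured compounds shown here, no measured step gives a readable size for this kind of change; every value so far is a limit. Compound 4 is therefore expected to remain at the limit, with an estimate of 60000 nM in the range 20000 nM to 200000 nM. The expected step that the limit leaves unreadable from compound 3 to compound 4 is accordingly not expected to be readable beyond the scatter.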

Compound 4, half-maximal inhibitory concentration: > 50000 nM
Compound 4 ended at the assay's limit (the forecaster's own chance of this, stated with the estimate: 80%); the middle value is on the limit's open side.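

The steps linking compound 1, compound 2 and compound 3 to compound 4 cannot be read in size, because each compound gives only a limit: the limit of > 50000 nM in this assay, at which 4 of the 4 values shown sit.

On these data alone, whether any change to the shared core yields a readable value stays open.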